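A few compounds are considered here, and "the series" means these few. Any claim that something is new, unique, unknown or untested is made for them only; others in the source may bear on it.

Measured so far:
compound 1, `COc1cc([C@H]2C[C@]2(CO)C(=O)Nc2ccccc2Cl)cc(OC)c1OC`, 45500 nM
compound 2, `CCOC(=O)[C@@]1(C(=O)Nc2ccccc2Cl)C[C@H]1c1cc(OC)c(OC)c(OC)c1`, 14400 nM
compound 3, `COc1cc([C@@H]2C[C@@]2(CO)C(=O)Nc2ccccc2)cc(OC)c1OC`, 86400 nM

All three were tested in a functional assay on HeLa cells (Homo sapiens) for cytotoxicity, read by MTT assay, with a stated time of 48 h; a lower number here means a stronger inhibitor, a higher number a weaker inhibitor. Compound 3 shows the highest number of the three. Its nearest neighbour is compound 1, which gives 45500 nM, a gap that sits within the usual scatter, so no order between these two can be claimed. Compound 2 stands furthest away and gives 14400 nM, a gap that lies beyond the scatter.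

The step now followed leads from compound 3 to compound 4, `COc1cc([C@@H]2C[C@@]2(CO)C(=O)Nc2ccccc2Cl)cc(OC)c1OC`, which has not yet been tested in this assay. The structural change is small: chloro in place of hydrogen on an aromatic carbon. Among the measured compounds shown here, no measured pair shows this change alone, so its effect has to be guessed from the surroundings. Compound 1, which also carries a (2-chlorophenyl)amino group, gives 45500 nM in this assay, a number close to that of compound 3. On that basis compound 4 is expected to move by a 1.7-fold lower number from compound 3 to compound 4 (0.24 log units; within the scatter), a modest shift toward a lower number that may well stay within the scatter. The estimate for compound 4 is therefore 50000 nM, with a range from 20000 nM to 130000 nM.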

Compound 4, half-maximal inhibitory concentration: 13300 nM
Estimate against measurement, compound 4: 3.8-fold (0.58 log units) above; the measured number lies below the stated range.
By their numbers in this assay, from the lowest: compounds 4 and 2 (each within the scatter of the next); then compounds 1 and 3 (each within the scatter of the next).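

In this assay, among the compounds shown here, chloro in place of hydrogen on an aromatic carbon, ortho to a large group, gives a 6.5-fold lower number from compound 3 to compound 4 (0.81 log units; beyond the scatter), so this change, read here alone for the first time, has an effect that clears the scatter. Configuration also matters at this level of substitution, as the two (2-chlorophenyl)amino compounds with hydroxymethyl give a 3.4-fold lower number from compound 1 to compound 4 (0.53 log units; beyond the scatter), and the gap can be set on nothing but their drawn stereocentres: the fact that compounds 1 and 4 differ only in the configuration as drawn. On the ester side, hydroxymethyl in place of ethoxycarbonyl on a saturated ring carbon gives a 1.1-fold lower number from compound 2 to compound 4 (0.03 log units; within the scatter), which lies within the scatter, so no order can be claimed between these two compounds.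

The compounds shown leave open whether the effect of chloro belongs to this one position and this one configuration, or whether it would also appear with the opposite configuration or with chloro elsewhere on the six-membered ring. They also leave open whether fluoro, bromo or methyl on that aromatic carbon would give a similar step, and whether a carboxylic acid or an aminomethyl group on the saturated ring carbon would keep the number of compound 4.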